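Replacing benzylamino with hydroxy on the shared core

This account rests on a few compounds, and the source may have more. Where it says the series, first, only, none or still open, it means among the compounds named here.

Compound 1 `COc1cccc(OC)c1C(=O)Nc1c[nH]nc1C(=O)NC1CC1`: > 50000 nM
Compound 2 `COc1cccc(OC)c1C(=O)Nc1c[nH]nc1C(=O)NN1CCOCC1`: > 50000 nM
Compound 3 `COc1cccc(OC)c1C(=O)Nc1c[nH]nc1C(=O)NCc1ccccc1`: 50000 nM

In an ADME assay on MRC5 cells (Homo sapiens) for inhibition, with a stated time of 72 h (a higher number here means that more compound is needed for the effect, a lower number that less compound is needed), compound 1 reaches only a limit, > 50000 nM. Compound 2 likewise reaches only a limit, > 50000 nM. Going by the values given here, compound 3 is the one compound with a number, 50000 nM, while the other two results sit at the limit of > 50000 nM in this assay, at which 2 of the 3 values shown sit. The steps of a number no higher from compound 1 to compound 3 (the limit leaves the size open) and a number no higher from compound 2 to compound 3 (the limit leaves the size open) are therefore of unreadable size, and both concern the amide-type nitrogen, not the carbonyl carbon. Compound 4 `COc1cccc(OC)c1C(=O)Nc1c[nH]nc1C(=O)O` differs from compound 3 by hydroxy in place of benzylamino on a carbonyl carbon. Among the compounds with values here, no measured step bears on this change, so no step beyond the usual scatter is expected in this assay; for compound 4 the estimate is 50000 nM, between 25000 nM and 100000 nM, an expected step of no change at the digits printed from compound 3 to compound 4 (within the scatter).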

Compound 4, half-maximal effective concentration: > 50000 nM
Compound 4: a limit, no number; the forecaster's own chance of this, stated with the estimate: 70%; the middle value sits exactly at the limit.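

In this assay, hydroxy in place of benzylamino on a carbonyl carbon gives a number no lower from compound 3 to compound 4 (the limit leaves the size open). This is the only change shown on the carbonyl carbon rather than on the amide-type nitrogen, and it yields a limit, so its size stays unknown. The steps to compound 4 from compound 1 and compound 2 cannot be read, and compound 3 remains the only compound with a number, with the others at one shared limit: the limit of > 50000 nM in this assay, at which 3 of the 4 values shown sit.

Going by these compounds, whether a methyl ester or a longer amine chain on this carbonyl carbon would give a number in this assay stays open.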